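The source may hold more compounds than are shown below. What is called first, only, known or untested is meant among the compounds shown, and "the series" means these compounds.

Measured so far:
compound 1, `CCn1c(N[C@H]2CC[C@H](C(=O)O)CC2)nc2ccsc2c1=O`: 450 ug/mL
compound 2, `CCn1c(NC(C)(C)C)nc2ccsc2c1=O`: 3.7 ug/mL

In a physicochemical assay for solubility, in phosphate buffer, at pH 6.8 (a higher number here means a more soluble compound, a lower number a less soluble compound), compound 1 gives 450 ug/mL and stands highest of the two numbers; the nearest of the rest, compound 2, gives 3.7 ug/mL, a gap well beyond the scatter. For the measured compounds named here, no two measured compounds differ in one place, so no single step is yet known. Compound 3, `CCn1c(N[C@H]2CC[C@H](C(=O)OC)CC2)nc2ccsc2c1=O`, is not yet measured in this assay. It differs from compound 1 in one place: methyl in place of hydrogen on an oxygen next to a carbonyl group. This change is expected to lower the number in this assay by a large margin, beyond the scatter, because compound 2, which also carries no carboxy group, gives 3.7 ug/mL. Compound 3 keeps the ring and the carbonyl, so the number is expected to sit above that of compound 2. The expected step is a 30-fold lower number from compound 1 to compound 3 (1.48 log units; beyond the scatter). Compound 3 is estimated at 15 ug/mL, with a range from 3 ug/mL to 80 ug/mL.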

Compound 3, solubility: 13 ug/mL
Compound 3: the middle estimate sits 1.2-fold (0.06 log units) above what was measured; the range from low to high includes it.
By their numbers in this assay, from the lowest: compound 2; then compound 3; then compound 1.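

Methyl in place of hydrogen on an oxygen next to a carbonyl group is the first single change that can be read in this series, and in this assay it gives a 35-fold lower number from compound 1 to compound 3 (1.54 log units; beyond the scatter), a large step beyond the scatter. Since compound 1 and compound 3 differ nowhere else, this one added carbon on the carboxy oxygen accounts for the full difference, so the read-out is highly sensitive to this position. Nothing at hand gives a measured cause for the size of this step.

Still open, going by these compounds, is whether any replacement for the carboxylic acid would give a similar step, or whether a primary amide, an amine or an ethyl ester would behave differently. On these data alone, it is also open whether a step of this size would recur with the carboxy group on a different side chain of the shared core.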